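The source may hold more compounds than are shown below. What is called first, only, known or untested is meant among the compounds shown, and "the series" means these compounds.

Measured compounds:
- compound 1, `CCCC(c1ccccc1)n1ccc2cc(/C(C)=C/C(=O)Nc3ccccc3OCCCC(=O)O)ccc21`: 9.1 nM
- compound 2, `CCCCC(c1ccccc1)n1ccc2cc(/C(C)=C/C(=O)Nc3ccccc3OCCCC(=O)O)ccc21`: 9.8 nM
- compound 3, `COc1ccc(C(c2ccccc2)n2ccc3cc(/C(C)=C/C(=O)Nc4ccccc4OCCCC(=O)O)ccc32)cc1`: 8.8 nM

In an assay on Prostate gland for inhibition of steroid 5-alpha-reductase (Rattus norvegicus) (on this read-out higher numbers stand for weaker inhibition and lower numbers for stronger inhibition), compound 3 gives 8.8 nM, formally the smallest of the three numbers, but the gaps to compound 1 and compound 2 are both within the usual scatter, so the three compounds cannot be told apart on this read-out.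

Compound 4, `C/C(=C\C(=O)Nc1ccccc1OCCCC(=O)O)c1ccc2c(ccn2C(c2ccccc2)c2cccnc2)c1`, differs from compound 3 in one place: pyridin-3-yl in place of 4-methoxyphenyl on a saturated chain carbon bound to an aromatic carbon and an aromatic nitrogen. The measured steps that touch this position are a 1.0-fold lower number from compound 1 to compound 3 (0.01 log units; within the scatter) and a 1.1-fold lower number from compound 2 to compound 3 (0.05 log units; within the scatter), where a propyl or butyl chain gave way to the 4-methoxyphenyl group. Neither moved the number beyond the scatter. Among the compounds with values here, no measured step exchanges one aromatic ring for another at this carbon, so nothing in the data suggests that pyridin-3-yl would behave differently from the groups already tried.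

The step from compound 3 to compound 4 is therefore expected to stay within the scatter, a 1.1-fold higher number from compound 3 to compound 4 (0.06 log units; within the scatter). Compound 4 is estimated at 10 nM, with a likely range from 4 nM to 25 nM.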

Compound 4, half-maximal inhibitory concentration: 47 nM
For compound 4 the middle estimate is 4.7-fold (0.67 log units) below the measured one; measured number above the stated range.
By their numbers in this assay, from the lowest: compounds 3, 1 and 2 (each within the scatter of the next); then compound 4.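

In this assay, this carbon proves sensitive to the group it carries: propyl, butyl and 4-methoxyphenyl could not be told apart, yet pyridin-3-yl weakens inhibition, with a 5.3-fold higher number from compound 3 to compound 4 (0.73 log units; beyond the scatter) and a 4.8-fold higher number from compound 2 to compound 4 (0.68 log units; beyond the scatter) and a 5.2-fold higher number from compound 1 to compound 4 (0.71 log units; beyond the scatter) all beyond the scatter. An aromatic ring is therefore not interchangeable with any other here, since a ring of carbon only carrying a methoxy group and a ring holding one nitrogen give different numbers. No available evidence accounts for this difference.

The compounds shown leave open whether the ring nitrogen or the missing methoxy group matters more, a question that a second plain phenyl at this carbon would address. They also leave open whether pyridin-2-yl or pyridin-4-yl would give the same number as pyridin-3-yl.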